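The source may hold more compounds than are shown below. What is called first, only, known or untested is meant among the compounds shown, and "the series" means these compounds.

Compound 1 `CCN1CCN(Cc2ccc(NC(=O)c3ccc(C)c(C#Cc4ccc(NC(C)=O)nc4)c3)cc2C(F)(F)F)CC1` serves as the starting point. In a functional assay on BaF3 cells (Mus musculus) for antiproliferative activity (a lower number here means that less compound is needed, a higher number that more compound is needed for the effect), compound 1 gives 2050 nM, the lowest of the three numbers at hand, though its neighbours sit close: compound 3 `CCN1CCN(Cc2ccc(NC(=O)c3ccc(C)c(C#Cc4cncnc4)c3)cc2C(F)(F)F)CC1` gives 2190 nM and compound 2 `CCN1CCN(Cc2ccc(NC(=O)c3ccc(C)c(C#Cc4ccc(C(=O)NC)nc4)c3)cc2C(F)(F)F)CC1` gives 3980 nM, so the differences are a 1.1-fold higher number from compound 1 to compound 3 (0.03 log units; within the scatter) and a 1.9-fold higher number from compound 1 to compound 2 (0.29 log units; within the scatter), with a 1.8-fold lower number from compound 2 to compound 3 (0.26 log units; within the scatter) between the other pair. All three variants at the triple-bonded carbon thus land at about the same place.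

Compound 4 `CCN1CCN(Cc2ccc(NC(=O)c3ccc(C)c(C#Cc4coc5ccccc45)c3)cc2C(F)(F)F)CC1` alters the same position: 1-benzofuran-3-yl in place of 6-acetamidopyridin-3-yl on a triple-bonded carbon. Among the compounds with values here, the steps that bear on it are those from compound 1 to compound 3 and from compound 1 to compound 2, both exchanges on the triple-bonded carbon and both within the scatter. Neither of them, however, tested a bicyclic group without a hydrogen-bond donor, so the evidence is indirect. On this basis compound 4 is expected to show no step beyond the scatter, that is a 1.2-fold higher number from compound 1 to compound 4 (0.09 log units; within the scatter), and its estimated value is 2500 nM, lying between 900 nM and 7000 nM.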

Compound 4, half-maximal effective concentration: 6760 nM
Compound 4: middle estimate off by 2.7-fold (0.43 log units), on the low side, within the range that was stated.
By their numbers in this assay, from the lowest: compounds 1, 3, 2 and 4 (each within the scatter of the next, the first and the last beyond it).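

In this assay, within the data shown here, the triple-bonded carbon proves not to accept every exchange equally: 1-benzofuran-3-yl gives a 3.3-fold higher number from compound 1 to compound 4 (0.52 log units; beyond the scatter) and a 3.1-fold higher number from compound 3 to compound 4 (0.49 log units; beyond the scatter) as the first steps at this place beyond the scatter, though both are modest. The change does not set compound 4 apart from every other compound, since the exchange for 6-(methylcarbamoyl)pyridin-3-yl gives a 1.7-fold higher number from compound 2 to compound 4 (0.23 log units; within the scatter) and so stays within the scatter. What sets 1-benzofuran-3-yl apart from the groups on compound 1 and compound 3 cannot be said, and no measurement at hand offers an explanation for these steps.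

As far as these compounds go, whether the steps follow from the whole 1-benzofuran-3-yl group or from one of its rings remains open, as a plain phenyl or furan-3-yl group on the triple-bonded carbon would be needed to tell. Also open, from the compounds shown here alone, is how a pyridin-3-yl group carrying an amine or a carboxylic acid would compare.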